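The source may report more compounds than this note shows. Statements on the series, on what has been measured and on what is new or still open speak of the compounds shown alone.

Compound 3 `O=C(Nc1ccc(Cl)cc1)C1CCCN(C(=O)c2cccc(-c3cccs3)c2)C1` gives 4% in an ADME assay on PC-3 cells (Homo sapiens) for cytotoxicity, read by WST assay, tested at 100 uM (a lower number here means less inhibition, a higher number more inhibition at the concentration tested (going by the name of the read-out)), the second highest of three numbers. Its nearest neighbour, compound 2 `Cc1nc(-c2cccc(C(=O)N3CCCC(C(=O)Nc4ccc(Cl)cc4)C3)c2)no1`, gives 0% in this assay, and compound 1 `O=C(Nc1ccc(Cl)cc1)C1CCCN(C(=O)c2cccc(-c3nccs3)c2)C1` gives 32%. Compound 4 `CS(=O)(=O)c1cccc(C(=O)N2CCCC(C(=O)Nc3ccc(Cl)cc3)C2)c1` differs from compound 3 in one place: methylsulfonyl in place of thiophen-2-yl on an aromatic carbon. Going by the values given here, two measured steps touch this aromatic carbon. The step of a number 28 percentage points lower from compound 1 to compound 3 (beyond the scatter) lay beyond the scatter, whereas a number 4 percentage points higher from compound 2 to compound 3 (within the scatter) stayed within it, so two of the three groups tried there gave low numbers. Among the compounds with values here, the methylsulfonyl group has no measured counterpart here. The step of a number 1 percentage points higher from compound 3 to compound 4 (within the scatter) is therefore expected to stay within the scatter. Compound 4 is estimated at 5%, within a range of -8% to 22%.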

Compound 4, a percentage reported as inhibition, at one concentration (the size of the read-out at that concentration, not a potency): 2%
For compound 4 the middle estimate is 3 percentage points above the measured one; the measured number falls inside the stated range.
By their numbers in this assay, from the lowest: compounds 2, 4 and 3 (each within the scatter of the next); then compound 1.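

In this assay the methylsulfonyl group, which has no ring, falls in with the thiophen-2-yl and 5-methyl-1,2,4-oxadiazol-3-yl groups, with a number 2 percentage points lower from compound 3 to compound 4 (within the scatter) and a number 2 percentage points higher from compound 2 to compound 4 (within the scatter). Only 1,3-thiazol-2-yl stands apart at this aromatic carbon, with a number 30 percentage points lower from compound 1 to compound 4 (beyond the scatter), so a low number no longer depends on an aromatic ring being present there. Nothing available explains why compound 1 differs from the other three.

The compounds shown leave open how a simple amine or a carboxylic acid at this carbon would read in this assay.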